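Swapping the Side Chain Guanidine for a Carbamoyl Group

The source may report more compounds than this note shows. Statements on the series, on what has been measured and on what is new or still open speak of the compounds shown alone.

Of the compounds shown here, three have been tested in a functional assay on the whole organism (Tail, strain ICR) with Mus musculus as the target, in the tail flick test, with a stated time of 150 min, at a dose of 25 umol/kg by the oral route; on this read-out higher numbers stand for a stronger effect at the one dose given and lower numbers for a weaker effect. Compound 1 `O=C(O)[C@@H]1CCCN1C(=O)CN(c1nc(Cl)nc2[nH]cnc12)C1CC1` gives 7.29%, compound 3 `O=C(OCc1ccccc1)[C@@H]1CCCN1C(=O)CN(c1nc(Cl)nc2[nH]cnc12)C1CC1` gives 31.1%, and compound 2 `N=C(N)NCCC[C@H](NC(=O)CN(c1ncnc2c1ncn2C1CCCCO1)C1CC1)C(=O)OCc1ccccc1` gives 19.6%, which places compound 2 second of the three, set apart from both others by more than the scatter. Among the compounds with values here, the only single-point step measured, a number 23.8 percentage points higher from compound 1 to compound 3 (beyond the scatter), concerns the ester end and says nothing about the side chain. Compound 4 `NC(=O)CC[C@H](NC(=O)CN(c1ncnc2c1ncn2C1CCCCO1)C1CC1)C(=O)OCc1ccccc1` differs from compound 2 by a group of 3 heavy atoms (1 carbon, 1 nitrogen, 1 oxygen; no ring) in place of a group of 5 heavy atoms (2 carbon, 3 nitrogen; no ring), on a saturated chain carbon, three bonds along the chain from an amide-type nitrogen and a carbonyl carbon. Within the data shown here, no measured step bears on this change, so no direction beyond the scatter can be foreseen in this assay. Compound 4 is therefore expected to give about 17%, with a range from 5% to 33%. The expected change is a number 2.6 percentage points lower from compound 2 to compound 4 (within the scatter), a step estimated to stay within the scatter.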

Compound 4, a percentage reported as activity, at one dose (the size of the read-out at that dose, not a potency): 10.7%
The estimate for compound 4 lay 6.3 percentage points above the measured number; the measured number falls inside the stated range.
By their numbers in this assay, from the lowest: compounds 1, 4 and 2 (each within the scatter of the next, the first and the last beyond it); then compound 3.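

In this assay, this position now has its first reading: carbamoyl in place of the group of 5 heavy atoms gives a number 8.9 percentage points lower from compound 2 to compound 4 (within the scatter). At this one dose, the side chain on this saturated chain carbon can therefore be shortened to a group of 3 heavy atoms with no change beyond the scatter. Nothing measured here bears on how either group acts. From the compounds shown here alone, whether an amine, a carboxylic acid or a longer chain at this place would move the number beyond the scatter remains open.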